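Benzyl in Place of Phenyl on the Urea of Compound 1

This account rests on a few compounds, and the source may have more. Where it says the series, first, only, none or still open, it means among the compounds named here.

Measured so far:
Compound 1, `Cc1ccc(S(=O)(=O)N[C@@H](CC(=O)NC(C)(C)C)C(=O)NCCNC(=O)Nc2ccccc2)cc1`, in an ADME assay on Karpas-1106P cells (Homo sapiens) for cytotoxicity (a lower number here means that less compound is needed, a higher number that more compound is needed for the effect), gives > 11100 nM.
Compound 2, `Cc1ccc(S(=O)(=O)N[C@@H](CC(=O)NC(C)(C)C)C(=O)NCCNC(=O)c2ccccc2Cl)cc1`, gives > 11100 nM.
Compound 3, `COc1cc(OC)cc(C(=O)NCCNC(=O)[C@H](CC(=O)NC(C)(C)C)NS(=O)(=O)c2ccc(C)cc2)c1`, gives > 11100 nM.

All three compounds share one core and differ only in the group attached to the last carbonyl carbon. For compound 1 the value is a limit of the assay, not a number. The same holds for compound 2. The same holds for compound 3. Compound 1 therefore does not stand at a measured position among these three; it sits at the limit of > 11100 nM in this assay, at which 3 of the 3 values shown sit, together with both of its neighbours.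

Compound 4, `Cc1ccc(S(=O)(=O)N[C@@H](CC(=O)NC(C)(C)C)C(=O)NCCNC(=O)NCc2ccccc2)cc1`, is not yet measured. It differs from compound 1 by benzyl in place of phenyl on an amide-type nitrogen. Of the measured steps, those from compound 1 are the closest comparisons, but a step that the two limits leave unreadable from compound 1 to compound 2 and a step that the two limits leave unreadable from compound 1 to compound 3 both stay unreadable, as does a step that the two limits leave unreadable from compound 2 to compound 3. Every value shown is a limit. Among the compounds with values here, no step among the measured compounds gives a size or a direction for a change at this position.

With nothing readable to lean on, the expectation for compound 4 is that it also reports only a limit in this assay, so the step of a number no higher from compound 1 to compound 4 (the limit leaves the size open) is expected to be none beyond the scatter. The estimate for compound 4 is 11100 nM, with a range from 5000 nM to 30000 nM.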

Compound 4, half-maximal effective concentration: > 11100 nM
Compound 4 ended at the assay's limit; the forecaster's own chance of this, stated with the estimate: 85%; the middle value lies on the limit itself.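

Compound 4 also sits at a limit of the assay and not at a number, so no step from compound 1, compound 2 or compound 3 to compound 4 can be read: the limit of > 11100 nM in this assay, at which 4 of the 4 values shown sit.

The compounds shown leave open how much compound, if any concentration reachable in this assay, would give the effect for any of them.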